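The source may report more compounds than this note shows. Statements on the series, on what has been measured and on what is new or still open speak of the compounds shown alone.

Values in an ADME assay on cells (Fibroblast, Gallus gallus) for cytotoxicity, read by CCK-8 assay, with a stated time of 48 h (a higher number here means that more compound is tolerated, a lower number that less compound is tolerated), each one a limit and not a number:

- Compound 1 `CCC(CC)O[C@@H]1C=C(C(=O)O)C[C@H](NCc2ccc(C(C)(C)C)cc2)[C@H]1NC(C)=O`: > 200000 nM
- Compound 2 `CCC(CC)O[C@@H]1C=C(C(=O)O)C[C@H](NCc2ccc(Sc3cccs3)cc2)[C@H]1NC(C)=O`: > 200000 nM
- Compound 3 `CCC(CC)O[C@@H]1C=C(C(=O)O)C[C@H](NCc2ccc(-c3cc4ccccc4s3)cc2)[C@H]1NC(C)=O`: > 200000 nM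

Compound 3 therefore has only a limit, > 200000 nM, and so do the other two compounds. Compound 4 `CCC(CC)O[C@@H]1C=C(C(=O)O)C[C@H](NCc2ccc(-c3csc4ccccc34)cc2)[C@H]1NC(C)=O` has the same atoms as compound 3, joined differently: 1-benzothiophen-3-yl in place of 1-benzothiophen-2-yl on an aromatic carbon. Two measured changes of the same group bear on this: a step that the two limits leave unreadable from compound 1 to compound 3 and a step that the two limits leave unreadable from compound 2 to compound 3. For the measured compounds named here, neither gives a size, so the only guide is the shared ceiling: the limit of > 200000 nM in this assay, at which 3 of the 3 values shown sit. No step beyond the usual scatter is expected in this assay, and no direction can be expected, because the limit of > 200000 nM in this assay, at which 3 of the 3 values shown sit, leaves every measured step unreadable. The estimated change is a step that the limit leaves unreadable from compound 3 to compound 4. For compound 4 the expected value is 250000 nM, within an estimated range of 130000 nM to 500000 nM.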

Compound 4, half-maximal cytotoxic concentration: > 200000 nM
Compound 4 was reported as a limit (the forecaster's own chance of this, stated with the estimate: 85%); the middle value lies beyond the limit too.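

No step can be read from compound 4 to compound 1, compound 2 or compound 3, because all of them sit at one shared ceiling: the limit of > 200000 nM in this assay, at which 4 of the 4 values shown sit.

On these data alone, whether these four compounds truly differ in this assay stays open.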